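The source may hold more compounds than are shown below. What is called first, only, known or untested is meant among the compounds shown, and "the series" means these compounds.

Compound 1 `CN(C)CCn1cnnc1-c1cc(Oc2ccc(NC(=O)N/N=C/c3ccc(Cl)cc3Cl)cc2F)ccn1` is the reference point of this comparison. Within the data shown here, in a functional assay on HT-29 cells (Homo sapiens) for cytotoxicity, read by MTT assay, with a stated time of 72 h (a lower number here means a stronger inhibitor, a higher number a weaker inhibitor), compound 1 gives 390 nM, the lowest of the three numbers measured so far. Compound 2 `CN(C)CCn1cnnc1-c1cc(Oc2ccc(NC(=O)N/N=C/c3ccc(F)cc3F)cc2F)ccn1` gives 960 nM in this assay. Compound 3 `CN(C)CCn1cnnc1-c1cc(Oc2ccc(NC(=O)N/N=C/c3cc(Br)c(O)c(Br)c3)cc2F)ccn1` gives 2670 nM in this assay, the highest of the three.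

The compound yet to be measured, compound 4 `CN(C)CCn1cnnc1-c1cc(Oc2ccc(NC(=O)N/N=C/c3ccc(O)c(F)c3)cc2F)ccn1`, differs from compound 1 in one place: 3-fluoro-4-hydroxyphenyl in place of 2,4-dichlorophenyl on a carbon with a double bond to nitrogen. Two measured steps speak to this change. Exchanging the 2,4-dichlorophenyl for a 2,4-difluorophenyl gave a 2.5-fold higher number from compound 1 to compound 2 (0.39 log units; beyond the scatter), a modest loss. Exchanging it for a 3,5-dibromo-4-hydroxyphenyl, which also brings a hydroxyl onto the ring, gave a 6.8-fold higher number from compound 1 to compound 3 (0.84 log units; beyond the scatter), a larger but still modest loss. The entering group of compound 4 shares a fluorine with compound 2 and a hydroxyl with compound 3, and both of those replacements made the number rise. A rise beyond the scatter is therefore expected here as well, most likely between the two measured losses. Compound 4 is thus expected to give about 1500 nM in this assay, with a plausible range from 500 nM to 4500 nM. This estimate corresponds to an expected step of a 3.8-fold higher number from compound 1 to compound 4 (0.59 log units; beyond the scatter).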

Compound 4, half-maximal inhibitory concentration: 3310 nM
The estimate for compound 4 lay 2.2-fold (0.34 log units) below the measured number; the range from low to high includes it.
By their numbers in this assay, from the lowest: compound 1; then compound 2; then compounds 3 and 4 (each within the scatter of the next).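

In this assay, the swap to 3-fluoro-4-hydroxyphenyl gives an 8.5-fold higher number from compound 1 to compound 4 (0.93 log units; beyond the scatter), so a ring with one fluorine and one hydroxyl fares far worse at this position than the 2,4-dichlorophenyl ring of the reference. The step of a 1.2-fold higher number from compound 3 to compound 4 (0.09 log units; within the scatter) shows that the two rings carrying a hydroxyl cannot be told apart here, even though one holds two bromines and the other a single fluorine. At the same time, a 3.4-fold higher number from compound 2 to compound 4 (0.54 log units; beyond the scatter) shows that the fluorinated rings do not behave alike, so among these four compounds the split follows the presence of a hydroxyl on the ring more closely than the kind of halogen, and no compound shown goes against it; nothing available here explains that split.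

From the compounds shown here alone, what remains open is whether the hydroxyl alone accounts for the rise, which a plain 4-hydroxyphenyl ring, free of any halogen, could test. A methoxy group or an amine in the place of the hydroxyl would show whether a different group there gives numbers closer to those of compound 1 or compound 3.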